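Vinyl dihydrofuran amides: aryl swap on the saturated ring carbon

This account rests on a few compounds, and the source may have more. Where it says the series, first, only, none or still open, it means among the compounds named here.

Measured so far in a functional assay on QGY7701 cells (Homo sapiens) for cytotoxicity, read by MTT assay, with a stated time of 24 h; a higher number here means a weaker inhibitor, a lower number a stronger inhibitor:
compound 1 `C=CC1=C(C(=O)NCC(C)C)C(c2ccc(Cl)c(Cl)c2)OC1`: > 100000 nM
compound 2 `C=CC1=C(C(=O)NC(C)(C)C)C(c2ccc(Cl)c(Cl)c2)OC1`: > 100000 nM
compound 3 `C=CC1=C(C(=O)NCc2ccccc2)C(c2ccc(F)cc2)OC1`: 67600 nM

In this assay compound 1 gives only a limit, > 100000 nM. Compound 2 likewise gives only a limit, > 100000 nM. Among the measured compounds shown here, compound 3 is the single compound with a number, 67600 nM, and so it stands alone; the other two values cannot be placed against it beyond noting (the limit of > 100000 nM in this assay, at which 2 of the 3 values shown sit).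

Compound 4 `C=CC1=C(C(=O)NCc2ccccc2)C(c2ccc(Cl)c(Cl)c2)OC1` is not yet measured. It differs from compound 3 by 3,4-dichlorophenyl in place of 4-fluorophenyl on a saturated ring carbon. For the measured compounds named here, the one measured step, a step that the two limits leave unreadable from compound 1 to compound 2, changes the amide substituent, not the aryl group, and is in any case not readable; it therefore says nothing about the size or direction of the present change. What remains is that compound 1 and compound 2, which already carry the 3,4-dichlorophenyl, sit at the limit.

On that basis the step from compound 3 to compound 4 is expected to be small or towards weaker inhibition, a 1.3-fold higher number from compound 3 to compound 4 (0.12 log units; within the scatter). Compound 4 is estimated at 90000 nM, with a range from 30000 nM to 300000 nM, and a real chance that this assay reports only a limit.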

Compound 4, half-maximal inhibitory concentration: > 100000 nM
Compound 4 gave a limit, no number; the forecaster's own chance of this, stated with the estimate: 45%; middle value at least 1.1-fold (0.04 log units) away from the limit.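

From the compounds shown here alone, exchanging 4-fluorophenyl for 3,4-dichlorophenyl on the saturated ring carbon next to the ring oxygen gives, in this assay, an at least 1.4-fold higher number from compound 3 to compound 4 (0.17 log units; that floor lies within the scatter); this is only a floor, so the true size of the step stays open, and the change shows no gain. Compound 4 gives > 100000 nM, which is a limit and not a number. With a benzyl group on the amide nitrogen, the 3,4-dichlorophenyl compound now sits with the other two compounds carrying that aryl group, and the steps among these three cannot be read: the limit of > 100000 nM in this assay, at which 3 of the 4 values shown sit.

Going by these compounds, only compound 3 gives a number, and the size of any aryl effect at this position remains open. Also open, on these data alone, is how a 4-methoxyphenyl or pyridyl group at this ring carbon would read in this assay.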